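A few compounds are considered here, and "the series" means these few. Any claim that something is new, unique, unknown or untested is made for them only; others in the source may bear on it.

Four compounds built on two related cores were examined in an assay on isolated protein for inhibition of ribosomal protein S6 kinase alpha-1 (Homo sapiens), read by mobility shift assay, tested at 30 uM; a lower number here means less inhibition, a higher number more inhibition at the concentration tested (going by the name of the read-out). Compound 1 `Cc1cc2c(c(N)nn2C)c(N2CCCCC2)n1` carries a piperidin-1-yl group, and in this assay compound 1 gives 23%. Compound 2 `COCCNc1nc(C)cc2c1c(N)nn2C` has the same core but a (2-methoxyethyl)amino group where compound 1 has the piperidin-1-yl, and in this assay compound 2 gives -4%. The change from compound 2 to compound 1, (piperidin-1-yl in place of (2-methoxyethyl)amino on an aromatic carbon), produced a number 27 percentage points higher from compound 2 to compound 1 (beyond the scatter).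

Compound 3 `COCCNc1nc(C)cc2nn(-c3ccccc3)c(N)c12` keeps the (2-methoxyethyl)amino group on a second core; how the two cores differ is not broken down here. In this assay compound 3 gives 2%, a number close to that of compound 2.

Compound 4 `Cc1cc2nn(-c3ccccc3)c(N)c2c(N2CCCCC2)n1` has not yet been measured; it is the piperidin-1-yl counterpart of compound 3. The change from compound 3 to compound 4 is piperidin-1-yl in place of (2-methoxyethyl)amino on an aromatic carbon, the same change as that between compound 2 and compound 1, and it occurs twice among these compounds. Within the data shown here, only that one earlier instance is available, so any expectation rests on it alone. The expected step is a number 23 percentage points higher from compound 3 to compound 4 (beyond the scatter), because a number 27 percentage points higher from compound 2 to compound 1 (beyond the scatter) was found for the same change on the other core, and the starting point of compound 3 resembles that of compound 2. Compound 4 is therefore estimated at 25%. Given a single precedent, compound 4 is expected to fall somewhere between 5% and 45%.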

Compound 4, a percentage reported as inhibition, at one concentration (the size of the read-out at that concentration, not a potency): 4%
Compound 4: middle estimate off by 21 percentage points, on the high side; measured number below the stated range.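

In this assay, placing piperidin-1-yl where compound 3 has (2-methoxyethyl)amino gave a number 2 percentage points higher from compound 3 to compound 4 (within the scatter), so the clear rise seen for this change on the core of compound 1 did not carry over to the second core. Set side by side, the two instances of the same change do not agree: the same change on two cores in this assay, a number 27 percentage points higher (beyond the scatter) from compound 2 to compound 1 and a number 2 percentage points higher (within the scatter) from compound 3 to compound 4, 25 percentage points apart, beyond the scatter of two such steps This shows that, for these two pairs, the effect of the change depends on the core that carries it, so a step measured on one core was not a safe guide to the other; it does not show which difference between the cores is responsible, how the change would behave on a third core, or how potency would shift, as each reading comes from a single concentration.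

The compounds shown leave open whether other groups on that aromatic carbon, such as a morpholin-4-yl ring, a dimethylamino group or a longer chain ending in an amine, would raise the number on either core. They also leave open whether such groups would separate the two cores as piperidin-1-yl does, or give similar numbers on both.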